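The source may report more compounds than this note shows. Statements on the series, on what has been measured and on what is new or still open speak of the compounds shown alone.

Working notes on the series in a functional assay on MCF7 cells (Homo sapiens) for antiproliferative activity, read by MTT assay; on this read-out higher numbers stand for weaker inhibition and lower numbers for stronger inhibition. Compound 1 (`COc1cc2c(Oc3ccc(NC(=O)Nc4ccccc4Cl)cc3)ccnc2cc1OCCCCCCC(=O)NO`) gives 2780 nM, compound 2 (`COc1cc2c(Oc3ccc(NC(=O)Nc4ccccc4C(F)(F)F)cc3)ccnc2cc1OCCCCCCC(=O)NO`) gives 1080 nM and compound 3 (`COc1cc2c(Oc3ccc(NC(=O)Nc4ccc(C(F)(F)F)cc4Cl)cc3)ccnc2cc1OCCCCCCC(=O)NO`) gives 500 nM. Compound 3 holds the lowest of the three numbers, and its steps to both others lie beyond the scatter.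

Next in line is compound 4 (`COc1cc2c(Oc3ccc(NC(=O)Nc4ccc(Cl)c(C(F)(F)F)c4)cc3)ccnc2cc1OCCCCCCC(=O)NO`), which carries the same atoms joined differently: 4-chloro-3-(trifluoromethyl)phenyl in place of 2-chloro-4-(trifluoromethyl)phenyl on an amide-type nitrogen. In words, 4-chloro-3-(trifluoromethyl)phenyl stands in place of 2-chloro-4-(trifluoromethyl)phenyl on an amide-type nitrogen.

Among the compounds with values here, no measured step rearranges groups in this way, so the evidence is indirect. The nearest guides are a 2.2-fold lower number from compound 2 to compound 3 (0.33 log units; beyond the scatter), a 2.6-fold lower number from compound 1 to compound 2 (0.41 log units; beyond the scatter) and a 5.6-fold lower number from compound 1 to compound 3 (0.75 log units; beyond the scatter), all modest. Across these three compounds, changes to this aryl group have moved the number only modestly, and none of the steps shows what the rearrangement itself will do. A large step in this assay is therefore not expected. Within the data shown here, the expectation is for no step clearly beyond the scatter, with a slight lean towards a higher number, and the estimated step is a 1.4-fold higher number from compound 3 to compound 4 (0.15 log units; within the scatter). For compound 4 the estimated value is 700 nM, with an expected range of 250 nM to 2000 nM.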

Compound 4, half-maximal inhibitory concentration: 5150 nM
The estimate for compound 4 lay 7.4-fold (0.87 log units) below the measured number, and the stated range ends below it.
By their numbers in this assay, from the lowest: compound 3; then compound 2; then compounds 1 and 4 (each within the scatter of the next).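

In this assay, within the data shown here, the rearrangement on the amide-type nitrogen is not a neutral change: 4-chloro-3-(trifluoromethyl)phenyl in place of 2-chloro-4-(trifluoromethyl)phenyl gives a 10-fold higher number from compound 3 to compound 4 (1.01 log units; beyond the scatter), the only large step so far. The earlier compounds shown here suggested that a richer aryl group goes with a lower number, but compound 4 goes against this: 4-chloro-3-(trifluoromethyl)phenyl in place of 2-(trifluoromethyl)phenyl gives a 4.8-fold higher number from compound 2 to compound 4 (0.68 log units; beyond the scatter), and in place of 2-chlorophenyl it gives a 1.9-fold higher number from compound 1 to compound 4 (0.27 log units; within the scatter), a step that stays within the scatter. Carrying both chloro and trifluoromethyl on this aryl group is therefore not enough for a low number, since compound 3 and compound 4 hold the same atoms and are separated only by how these groups are arranged.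

Nothing in the data at hand accounts for the size of this step. These four compounds cannot separate the part played by the chloro from that of the trifluoromethyl in the rearrangement, and they leave open how a nitrile or an amine in place of the chloro would read.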